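Amide-to-acryloyl change on the piperidine of the sulfonamide series

A few compounds are considered here, and "the series" means these few. Any claim that something is new, unique, unknown or untested is made for them only; others in the source may bear on it.

Measured compounds:
compound 1 `Cn1cncc1CN1CC(N(CC2CCN(C(=O)CNC(=O)OC(C)(C)C)CC2)S(=O)(=O)c2ccccn2)Cc2cc(C#N)ccc21` gives 0.5 10^-6 cm/s in an ADME assay on Caco-2 cells (Homo sapiens) for permeability, in the apical to basolateral direction; a higher number here means that the compound crosses the layer faster, a lower number that the compound crosses the layer more slowly
compound 2 `CC(C)NC(=O)N1CCC(CN(C2Cc3cc(C#N)ccc3N(Cc3cncn3C)C2)S(=O)(=O)c2ccccn2)CC1` gives 0.6 10^-6 cm/s in this assay

Compound 2 holds the highest of the two numbers recorded in this assay, but its nearest neighbour is compound 1, and the step of a 1.2-fold higher number from compound 1 to compound 2 (0.08 log units; within the scatter) is within the scatter, so the two values cannot be ordered.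

Compound 3 `C=C(C)C(=O)N1CCC(CN(C2Cc3cc(C#N)ccc3N(Cc3cncn3C)C2)S(=O)(=O)c2ccccn2)CC1` is unmeasured. It differs from compound 2 by 1-methylethenyl in place of isopropylamino on a carbonyl carbon. Read one bond further out, the change is isopropylcarbamoyl to (1-methylethenyl)carbonyl on the piperidine nitrogen.

Among the measured compounds shown here, only one measured step exists, a 1.2-fold higher number from compound 1 to compound 2 (0.08 log units; within the scatter), and it concerns the other end of the same carbonyl, swapping one amino substituent for another; it does not bear on the exchange of an amino group for a carbon substituent. The series therefore gives no direct guide. Compound 3 is expected to sit near compound 2, with a modest rise possible, the estimated step being a 1.7-fold higher number from compound 2 to compound 3 (0.22 log units; within the scatter). Compound 3 is estimated at 1 10^-6 cm/s, with a range from 0.4 10^-6 cm/s to 2.5 10^-6 cm/s.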

Compound 3, apparent permeability: 0.5 10^-6 cm/s
Estimate against measurement, compound 3: 2.0-fold (0.30 log units) above, and the stated range covers the measured number.
By their numbers in this assay, from the lowest: compounds 1, 3 and 2 (each within the scatter of the next).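

In this assay the exchange of an amino substituent on the carbonyl for a carbon substituent gives a 1.2-fold lower number from compound 2 to compound 3 (0.08 log units; within the scatter), so removing isopropylamino, which carries a hydrogen-bond donor, and introducing 1-methylethenyl, which carries none, leaves no readable difference. The second new pair gives no change at the digits printed from compound 1 to compound 3 (within the scatter), so ((tert-butoxycarbonyl)amino)methyl, isopropylamino and 1-methylethenyl on this carbonyl all give values that cannot be told apart, and among these three compounds the position shows no readable response to the substituent. Nothing available accounts for this flat reading.

As far as these compounds go, whether an amine or a carboxylic acid on this carbonyl, or a longer chain in place of 1-methylethenyl, would move the number beyond the scatter remains open. All three compounds share the rest of the structure, so the series says nothing yet about changes elsewhere, such as replacing the nitrile or the pyridine-free parts of the shared core with another group.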